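The source may report more compounds than this note shows. Statements on the series, on what has been measured and on what is new or still open speak of the compounds shown alone.

Working notes on the dioxino-substituted oxadiazolethione series. Compound 1 `Fc1ccccc1N1CCN(Cn2nc(-c3ccc4c(c3)OCCO4)oc2=S)CC1` gives 37300 nM in a functional assay on HeLa cells (Homo sapiens) for antiproliferative activity, read by MTT assay, with a stated time of 48 h; on this read-out lower numbers stand for stronger inhibition and higher numbers for weaker inhibition. Compound 2 `S=c1oc(-c2ccc3c(c2)OCCO3)nn1CN1CCN(c2ccccc2)CC1` reaches in this assay only the limit > 50000 nM, which is a limit of the assay and not a number. Within the data shown here, the one step measured so far, an at least 1.3-fold higher number from compound 1 to compound 2 (0.12 log units; that floor lies within the scatter), replaces fluoro on an aromatic carbon with hydrogen; its size is known only as a floor, set by the limit of > 50000 nM in this assay, at which 1 of the 2 values shown sits.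

Compound 3 `Fc1ccc(N2CCN(Cn3nc(-c4ccc5c(c4)OCCO5)oc3=S)CC2)cc1` is drawn from compound 2 by fluoro in place of hydrogen on an aromatic carbon. Among the measured compounds shown here, the only measured step that bears on this change is the one from compound 1 to compound 2, run in the opposite sense and with a floor inside the scatter, so in this assay no step beyond the scatter is expected, in either direction, and the chance of another limit remains high. For compound 3 the estimate in this assay is 45000 nM, with a range from 20000 nM to 120000 nM, an expected step of an at least 1.1-fold lower number from compound 2 to compound 3 (0.04 log units; that floor lies within the scatter).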

Compound 3, half-maximal inhibitory concentration: > 50000 nM
Compound 3 gave a limit, no number; the forecaster's own chance of this, stated with the estimate: 55%; at least 1.1-fold (0.04 log units) between middle value and limit.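

Fluoro on the aromatic carbon para to a large group, phenyl to 4-fluorophenyl, leaves compound 2 and compound 3 both at a limit of the assay and not at a number in this assay, so the step between them cannot be read: the limit of > 50000 nM in this assay, at which 2 of the 3 values shown sit.

Set against the 2-fluorophenyl of compound 1, the 4-fluorophenyl gives an at least 1.3-fold higher number from compound 1 to compound 3 (0.12 log units; that floor lies within the scatter), so only a floor is known and it does not separate the two placements. A fluoro on the phenyl does not by itself bring a number on this read-out: compound 1 has one and compound 3 does not.

From the compounds shown here alone, whether the true values of compound 2 and compound 3 differ stays open. Also open, going by these compounds, is whether a chloro, a methoxy or an amine on this phenyl gives a number clear of the limit in this assay.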